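The source may hold more compounds than are shown below. What is called first, only, known or untested is meant among the compounds shown, and "the series" means these compounds.

Measured so far:
compound 1 `CNC(=O)CC1CCc2cc(OC)c(OC)cc21` — 29.7%
compound 2 `CCCNC(=O)CC1CCc2cc(OC)c(OC)cc21` — 26.6%
compound 3 `CCCCCCNC(=O)CC1CCc2cc(OC)c(OC)cc21` — 42.1%

In a functional assay on the whole organism (strain Wistar) for inhibition, with Rattus norvegicus as the target, read by paw edema, with stated times of 60 min and 4 h, at a dose of 100 mg/kg by the oral route (a lower number here means less inhibition, a higher number more inhibition at the dose given (going by the name of the read-out)), compound 3 stands highest of the three: a number 12.4 percentage points higher from compound 1 to compound 3 (beyond the scatter) and a number 15.5 percentage points higher from compound 2 to compound 3 (beyond the scatter), both beyond the scatter, while a number 3.1 percentage points lower from compound 1 to compound 2 (within the scatter) stays within it. Every measured step lengthens the chain on the amide-type nitrogen; the two longer chains gave a modest rise.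

Compound 4 `COc1cc2c(cc1OC)C(CC(=O)NC1CCCCC1)CC2` is the next candidate. The change from compound 3 is cyclohexyl in place of hexyl on an amide-type nitrogen. Within the data shown here, no measured step trades a chain for a ring, and the count of heavy atoms is unchanged, so the measured steps give no direction here. A step within the scatter is expected: a number 2.1 percentage points lower from compound 3 to compound 4 (within the scatter). Compound 4 is expected near 40%, between 25% and 55%.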

Compound 4, a percentage reported as inhibition, in the whole organism at one dose (the size of the read-out at that dose, not a potency): 50%
For compound 4 the middle estimate is 10 percentage points below the measured one, and the stated range covers the measured number.
By their numbers in this assay, from the lowest: compounds 2 and 1 (each within the scatter of the next); then compounds 3 and 4 (each within the scatter of the next).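

On the amide-type nitrogen, cyclohexyl can take the place of hexyl with the heavy-atom count unchanged and no clear shift in this assay: a number 7.9 percentage points higher from compound 3 to compound 4 (within the scatter). Like hexyl, cyclohexyl also stands clear of the shorter groups, with a number 23.4 percentage points higher from compound 2 to compound 4 (beyond the scatter) and a number 20.3 percentage points higher from compound 1 to compound 4 (beyond the scatter). No measurement here explains these numbers.

Going by these compounds, whether a cyclopentyl ring, a phenyl ring or a chain ending in an amine on this nitrogen would hold the same level remains open. On these data alone, a carboxylic acid at that chain end is equally open.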